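Amide change at the weak end of the series

The source may hold more compounds than are shown below. What is called first, only, known or untested is meant among the compounds shown, and "the series" means these compounds.

In a functional assay on Caco-2 cells (Homo sapiens), read by MTT assay, with a stated time of 48 h (a higher number here means a weaker inhibitor, a lower number a stronger inhibitor), compound 1 `C#CCNC(=O)c1ccc(C(CC)(CC)c2ccc(OCC(O)C(C)(C)C)c(C)c2)n1CC` gives 39100 nM. Compound 2 `CCn1c(C(=O)NCC(OC)OC)ccc1C(CC)(CC)c1ccc(OCC(O)C(C)(C)C)c(C)c1` gives only a limit of the assay, > 50000 nM. That places it at the limit of > 50000 nM in this assay, at which 1 of the 2 values shown sits. Compound 3 `CCn1c(C(=O)N(CCC#N)CCC#N)ccc1C(CC)(CC)c1ccc(OCC(O)C(C)(C)C)c(C)c1` carries a new group on a carbonyl carbon: a group of 9 heavy atoms (6 carbon, 3 nitrogen; no ring) in place of a group of 7 heavy atoms (4 carbon, 1 nitrogen, 2 oxygen; no ring), on a carbonyl carbon. Among the measured compounds shown here, the one measured step bearing on this, an at least 1.2-fold higher number from compound 1 to compound 2 (0.10 log units; that floor lies within the scatter), also alters the amide substituent, and its floor stays within the scatter. No change beyond the scatter is therefore expected in this assay. The expected step is a number no higher from compound 2 to compound 3 (the limit leaves the size open). For compound 3 the estimate is 50000 nM, with an expected range of 22000 nM to 110000 nM.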

Compound 3, half-maximal inhibitory concentration: 7100 nM
Compound 3: middle estimate off by 7.0-fold (0.85 log units), on the high side; the whole stated range lies above it.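

At this carbonyl carbon, the amide group can shift the number in this assay beyond the scatter, which the earlier step did not show: the reading is an at least 7.0-fold lower number from compound 2 to compound 3 (0.84 log units; beyond the scatter), and a 5.5-fold lower number from compound 1 to compound 3 (0.74 log units; beyond the scatter). The first of these steps is only a floor, as the reading for compound 2 is a limit and not a number: the limit of > 50000 nM in this assay, at which 1 of the 3 values shown sits.

The compounds shown do not separate the loss of the amide hydrogen from the presence of the nitrile-bearing chains. A dimethylamino group on the same carbonyl carbon would tell these two apart.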